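The source may hold more compounds than are shown below. What is called first, only, known or untested is meant among the compounds shown, and "the series" means these compounds.

Measured so far:
- compound 1 `[N-]=[N+]=NCC(O)Cn1c(=O)n(C2OC(CO)[C@@H](O)[C@H]2O)c2nc(N)nc(O)c21` gives 91%
- compound 2 `C=CCn1c(=O)n(C2C[C@H](O)C(CO)O2)c2nc(N)nc(O)c21` gives 99%
- compound 3 `Cn1c(=O)n([C@@H]2O[C@H](CO)[C@H]3OC(C)(C)O[C@H]32)c2nc(N)nc(O)c21` gives 193%

All three compounds were tested in a functional assay on the whole organism (B cells) with Mus musculus as the target; a higher number here means a larger maximal response, a lower number a smaller maximal response. Compound 1 stands lowest of the three numbers. Its nearest neighbour is compound 2, whose value lies higher by an amount that is within the usual scatter of this assay, so no order between compound 1 and compound 2 can be claimed. The furthest number belongs to compound 3, which lies beyond the scatter above compound 1. Within the data shown here, only three values are known, and no pair of measured compounds differs in a single place, so no measured step can be put beside the change considered here.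

Compound 4 `N#Cc1ccc(Cn2c(=O)n(C3OC(CO)[C@@H](O)[C@H]3O)c3nc(N)nc(O)c32)cc1` has not yet been measured in this assay. It is derived from compound 1 by one change: 4-cyanophenyl in place of 2-azido-1-hydroxyethyl on a saturated chain carbon bound to an aromatic nitrogen. The two measured compounds that carry a longer group on that chain carbon, compound 1 and compound 2, lie close together, while compound 3 stands apart; on this basis alone the account expects the step of a number 9 percentage points higher from compound 1 to compound 4 (within the scatter) to stay within the scatter, with no clear direction. Compound 4 is therefore estimated at 100%, with a range from 60% to 160%.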

Compound 4, largest response reached (reported as maximal response), in percent of the reference or control that the assay uses: 50%
Beside the measured number, compound 4's estimate is 50 percentage points above it, outside the stated range (below it).
By their numbers in this assay, from the lowest: compound 4; then compounds 1 and 2 (each within the scatter of the next); then compound 3.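

In this assay, the group on this saturated chain carbon bound to an aromatic nitrogen proves to matter: 4-cyanophenyl in place of 2-azido-1-hydroxyethyl gives a number 41 percentage points lower from compound 1 to compound 4 (beyond the scatter), a large step and the first one measured at this place. The earlier compounds shown here could not show this, as no two of them differed in a single place, so the position's sensitivity to a change of group could not be read from them. Nothing measured here accounts for the size of this step.

The change is also several changes at once: the hydroxyl and azido parts of the chain leave, while a six-membered aromatic ring of carbon only and a nitrile enter, and this one step cannot separate their contributions. Going by these compounds, it remains open whether a plain benzyl group without the nitrile would give a number nearer to that of compound 4 or to that of compound 1, and how a chain ending in an amine or a carboxylic acid would behave at this place.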